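The compounds below may be only part of what the source reports. "The series", "measured", "known", "first", "only" and "open" are said of these compounds alone.

Compound 1 `COc1ccc(CN2C(=O)C(=O)c3cc(-c4ccc(OC)cc4)ccc32)cc1` — in a functional assay on HepG2 cells (Homo sapiens) for antiproliferative activity, read by MTT assay, with a stated time of 48 h (a higher number here means a weaker inhibitor, a lower number a stronger inhibitor), compound 1 gives 50 nM.
Compound 2 `COc1ccc(CN2C(=O)C(=O)c3cc(-c4cc(OC)cc(OC)c4)ccc32)cc1` — in this assay compound 2 gives 1200 nM.
Compound 3 `COc1ccc(CN2C(=O)C(=O)c3cc(-c4ccc5ccccc5c4)ccc32)cc1` — in this assay compound 3 gives > 10000 nM, which is a limit of the assay and not a number.

Compound 3 thus sits at the limit of > 10000 nM in this assay, at which 1 of the 3 values shown sits, the weakest position among the three measured compounds. Compound 4 `COc1ccc(CN2C(=O)C(=O)c3cc(-c4ccncc4)ccc32)cc1` differs from it by pyridin-4-yl in place of naphthalen-2-yl on an aromatic carbon. Among the compounds with values here, two measured steps bear on this change, both replacing a smaller aryl group by naphthalen-2-yl: an at least 200-fold higher number from compound 1 to compound 3 (2.30 log units; beyond the scatter) and an at least 8.3-fold higher number from compound 2 to compound 3 (0.92 log units; beyond the scatter). Reversing that direction, a return to a single six-membered ring, is therefore expected to bring a large step downward in this assay, estimated as an at least 12-fold lower number from compound 3 to compound 4 (1.09 log units; beyond the scatter). Compound 4 is accordingly expected to give about 800 nM in this assay, within a range of 100 nM to 8000 nM.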

Compound 4, half-maximal inhibitory concentration: > 10000 nM
Compound 4 gave a limit, no number; the forecaster's own chance of this, stated with the estimate: 15%; middle value at least 12-fold (1.09 log units) away from the limit.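

In this assay, a single six-membered aromatic ring at this position is not enough to keep activity: pyridin-4-yl brings an at least 200-fold higher number from compound 1 to compound 4 (2.30 log units; beyond the scatter) and an at least 8.3-fold higher number from compound 2 to compound 4 (0.92 log units; beyond the scatter). The step from compound 3 to compound 4 cannot be read, since both values are limits of the assay. Compound 4 shares that limit with compound 3: the limit of > 10000 nM in this assay, at which 2 of the 4 values shown sit.

From the compounds shown here alone, how an unsubstituted phenyl or a 4-hydroxyphenyl group would fare at this place remains open. So does whether the activity of compound 1 depends on its methoxy group or on its ring of carbon only.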